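A few compounds are considered here, and "the series" means these few. Any claim that something is new, unique, unknown or untested is made for them only; others in the source may bear on it.

Measured compounds in a functional assay on CRL2813 cells (Homo sapiens) for antiproliferative activity, read by sulforhodamine B assay, with a stated time of 5 days; on this read-out higher numbers stand for weaker inhibition and lower numbers for stronger inhibition:
- compound 1, `C#CCOc1ccc(C(C)(C)C)cc1C1(c2ccccc2)C(=O)Nc2ccccc21`: > 20000 nM.
- compound 2, `COc1ccc(C2(c3cc(C(C)(C)C)ccc3O)C(=O)Nc3c2ccc(F)c3F)cc1`: 3000 nM.
- compound 3, `CC(C)(C)c1ccc(O)c(C2(c3ccc(O)cc3)C(=O)Nc3ccccc32)c1`: 4000 nM.

For compound 1 the entry > 20000 nM is a limit of this assay, not a number. Of the two entries that are numbers, compound 2 stands at one end; compound 3 sits within the scatter of it, so the two cannot be told apart on this read-out. Going by the values given here, compound 2 and compound 3 differ both in the methoxy against hydroxy group and in the fluorines on the shared core, and no single step between them has been measured, so only their two values can be compared.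

Compound 4, `CC(C)(C)c1ccc(O)c(C2(c3ccc(O)cc3)C(=O)Nc3c2ccc(F)c3F)c1`, has not yet been measured in this assay. It differs from compound 2 by hydrogen in place of methyl on an oxygen on an aromatic ring; one heavy atom leaves and no ring or charge changes. The pair compound 2 and compound 3 shows that the methoxy-to-hydroxy exchange, taken together with the fluorine change, leaves the value within the scatter. On that basis the step from compound 2 to compound 4 is expected to be small, within the scatter, with no clear direction, as no change at the digits printed from compound 2 to compound 4 (within the scatter). Compound 4 is therefore estimated at 3000 nM in this assay, in the range 1000 nM to 9000 nM.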

Compound 4, half-maximal inhibitory concentration: 10700 nM
For compound 4 the middle estimate is 3.6-fold (0.55 log units) below the measured one, and the stated range ends below it.
By their numbers in this assay, from the lowest: compounds 2 and 3 (each within the scatter of the next); then compound 4. At a limit, above all of these: compound 1.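

The exchange of 4-methoxyphenyl to 4-hydroxyphenyl, read on its own with the fluorines of the shared core held in place, gives a 3.6-fold higher number from compound 2 to compound 4 (0.55 log units; beyond the scatter) in this assay, so the methyl on this oxygen counts on this core. The earlier pair, which differed in two places at once, could not show this, and its closeness now appears specific to that pair rather than a sign that the exchange is neutral: with the hydroxy group kept and the fluorines absent, compound 3 gives 4000 nM, while with the fluorines present compound 4 gives 10700 nM. Compound 1 carries a limit of the assay rather than a number, so it marks only the upper end of the scale on which these values are read: the limit of > 20000 nM in this assay, at which 1 of the 4 values shown sits.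

It remains open whether the same exchange gives a step of similar size on the core without fluorines, as the series shown holds no methoxy partner for compound 3. On these data alone, it also remains open how an ethoxy group, a longer ether chain or an amine in this place on the aromatic ring would compare with methoxy and hydroxy.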